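Lengthening the ether chain of compound 2

The compounds below may be only part of what the source reports. "The series", "measured", "known", "first", "only" and "open" are said of these compounds alone.

Three compounds have so far been measured in an assay on HEK293 cells for inhibition of potassium channel subfamily T member 1 (Homo sapiens), read by thallium flux; on this read-out higher numbers stand for weaker inhibition and lower numbers for stronger inhibition:

Compound 1 `CC1CCN(S(=O)(=O)N2CCN(CC(=O)Nc3cc(Cl)ccc3OC(C)C)CC2)CC1`: 5100 nM
Compound 2 `CCOc1ccc(Cl)cc1NC(=O)CN1CCN(S(=O)(=O)N2CCC(C)CC2)CC1`: 7100 nM
Compound 3 `COc1ccc(Br)cc1NC(=O)CN1CCN(S(=O)(=O)N2CCC(C)CC2)CC1`: 1400 nM

Compound 2 gives the highest number of the three. Its nearest neighbour is compound 1, reached by a 1.4-fold higher number from compound 1 to compound 2 (0.14 log units; within the scatter), a change that shortened the chain on the ring oxygen. Its furthest is compound 3, reached by a 5.1-fold lower number from compound 2 to compound 3 (0.71 log units; beyond the scatter), where the whole aromatic ring was exchanged.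

Compound 4 `CCCOc1ccc(Cl)cc1NC(=O)CN1CCN(S(=O)(=O)N2CCC(C)CC2)CC1` differs from compound 2 by methyl in place of hydrogen on a saturated chain carbon, two bonds along the chain from an oxygen on an aromatic ring. The step from compound 1 to compound 2 is the one that bears on this, as it too changed only the length of the same chain and stayed within the scatter; the step to compound 3 concerns a different part and says nothing here. On that basis the step from compound 2 to compound 4 is expected to stay within the scatter, a 1.1-fold lower number from compound 2 to compound 4 (0.04 log units; within the scatter). Compound 4 is therefore estimated at 6500 nM, with a range from 2500 nM to 16000 nM.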

Compound 4, half-maximal inhibitory concentration: 4300 nM
Compound 4: middle estimate off by 1.5-fold (0.18 log units), on the high side; the measured number falls inside the stated range.
By their numbers in this assay, from the lowest: compound 3; then compounds 4, 1 and 2 (each within the scatter of the next).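

In this assay, ethoxy to propoxy gives a 1.7-fold lower number from compound 2 to compound 4 (0.22 log units; within the scatter), so this extra methyl on the chain makes no measurable difference. Within the data shown here, the straight propyl chain and the branched isopropyl chain of equal size also cannot be told apart, with a 1.2-fold lower number from compound 1 to compound 4 (0.07 log units; within the scatter), which the earlier compounds could not show. Nothing measured here explains why these chains on the ring oxygen read alike.

Still open, going by these compounds, is whether a longer chain, such as butyl, would stay within the scatter. A chain ending in an amine or a carboxylic acid on the same oxygen is equally untested by these compounds.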